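A few compounds are considered here, and "the series" means these few. Any claim that something is new, unique, unknown or untested is made for them only; others in the source may bear on it.

Measured compounds:
compound 1, `CCC(C)(C)C(=O)N(O)Cc1ccc(F)c(F)c1F`, 49.9 uL/min
compound 2, `CCC(C)(C)C(=O)N(O)Cc1cc(F)c(F)c(F)c1`, 87.8 uL/min
compound 3, `CCC(C)(C)C(=O)N(O)Cc1ccc(F)cc1`, 28.8 uL/min

These three compounds share a core and differ only in the fluorine pattern on the aromatic ring. In an ADME assay on microsomes from liver (Mus musculus) for metabolic stability, read by LC-MS, using NADPH (on this read-out higher numbers stand for fast clearance and lower numbers for slow clearance), compound 3 gives 28.8 uL/min, the lowest of the three numbers. The nearest neighbour is compound 1 with 49.9 uL/min, which lies within the usual scatter of compound 3, so the two cannot be ranked against each other. Compound 2, with 87.8 uL/min, sits beyond the scatter above compound 3, so this pair does show a real gap. Within the data shown here, no single-change step between measured compounds is present in this set.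

Compound 4, `CCC(C)(C)C(=O)N(O)Cc1ccc(F)c(F)c1`, has not yet been measured in this assay. It is made from compound 3 by one change: fluoro in place of hydrogen on an aromatic carbon. The two trifluoro compounds do not point in one direction, since compound 1 lies within the scatter of compound 3 while compound 2 lies beyond it. The step from compound 3 to compound 4 in this assay is therefore expected to be small and upward, a 1.5-fold higher number from compound 3 to compound 4 (0.16 log units; within the scatter), not clearly beyond the scatter. On that basis compound 4 is estimated to give 42 uL/min in this assay, with a range from 22 uL/min to 78 uL/min.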

Compound 4, intrinsic clearance in a liver preparation (reported as CLH), per the amount of preparation that the assay uses: 61.4 uL/min
For compound 4 the middle estimate is 1.5-fold (0.16 log units) below the measured one, and the stated range covers the measured number.
By their numbers in this assay, from the lowest: compounds 3, 1, 4 and 2 (each within the scatter of the next, the first and the last beyond it).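

In this assay, among these compounds, the step of a 2.1-fold higher number from compound 3 to compound 4 (0.33 log units; beyond the scatter) is the first single change in this set, and it lies beyond the scatter: one fluoro in place of hydrogen, ortho to a fluoro group and meta to a large group, is enough on its own to give a modest but real rise in clearance. Going on to the two trifluoro compounds adds nothing that can be read, since the steps of a 1.4-fold lower number from compound 2 to compound 4 (0.16 log units; within the scatter) and a 1.2-fold higher number from compound 1 to compound 4 (0.09 log units; within the scatter) both lie within the scatter, so the one further fluoro that separates compound 4 from each of them shows no effect of its own in this assay, and the single readable change among these steps is the one that starts from compound 3. Nothing at hand speaks to why this one step has the size it has.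

On these data alone, it remains open whether a chloro, a methoxy or a nitrile on this same aromatic carbon would behave as the fluoro does. As far as these compounds go, it is equally open whether the same step would hold with a different acyl chain on the shared core, such as a longer chain.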